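A few compounds are considered here, and "the series" means these few. Any claim that something is new, unique, unknown or untested is made for them only; others in the source may bear on it.

Measured so far:
compound 1, `Nc1scc(-c2cccc(C(F)(F)F)c2)c1C(=O)c1ccccc1`, 59%
compound 2, `COc1cccc(-c2csc(N)c2C(=O)c2ccccc2)c1`, 34%

Among the compounds with values here, in a functional assay on CHO cells for agonist activity at adenosine receptor A1 (Homo sapiens), read by fluorescence and ERK phosphorylation, with stated times of 30 min and 1.5 h, tested at 10 uM (on this read-out lower numbers stand for a weaker effect and higher numbers for a stronger effect at the one concentration tested), compound 1 gives 59%, the higher of the two numbers in hand; compound 2 follows at 34%, and the one measured step, a number 25 percentage points lower from compound 1 to compound 2 (beyond the scatter), lies beyond the scatter.

Compound 3, `Nc1scc(-c2cccc(C(F)(F)F)c2)c1C(=O)c1ccc(Cl)cc1`, is not yet measured. It differs from compound 1 by chloro in place of hydrogen on an aromatic carbon, the change sitting on the ring attached to the carbonyl rather than on the ring that was altered between compound 1 and compound 2. Within the data shown here, no measured step touches that ring, so the step from compound 1 to compound 2 bears on it only indirectly, showing that a single aromatic substitution can shift this read-out by a modest amount. Among the measured compounds shown here, with no direct precedent, a step of at most modest size, in either direction, or none beyond the scatter is expected: a number 4 percentage points lower from compound 1 to compound 3 (within the scatter). Compound 3 is therefore estimated at 55%, within a range of 30% to 80%.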

Compound 3, a percentage reported as activity, at one concentration (the size of the read-out at that concentration, not a potency): 73%
Beside the measured number, compound 3's estimate is 18 percentage points below it; low and high end bracket the measured number.
By their numbers in this assay, from the lowest: compound 2; then compound 1; then compound 3.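

In this assay, the ring attached to the carbonyl proves responsive to substitution: going from phenyl to 4-chlorophenyl gives a number 14 percentage points higher from compound 1 to compound 3 (beyond the scatter). Within the data shown here, the only earlier step, a number 25 percentage points lower from compound 1 to compound 2 (beyond the scatter), changed a group on the other aromatic ring and lowered the number, whereas this single added chloro, placed para to a large group, shows that a change on the shared core can also raise it. Nothing available explains why this chloro raises the number.

The compounds shown leave open whether the rise is specific to chloro or would also appear with bromo or an amine at the same place, and whether it would carry over to the core of compound 2. On these data alone, the read-out reflects one concentration, and the higher number stands for a stronger effect at that concentration only; whether the effect would also be stronger at other concentrations remains open.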